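A few compounds are considered here, and "the series" means these few. Any claim that something is new, unique, unknown or untested is made for them only; others in the source may bear on it.

Compound 1 `O=C1Nc2ccc([N+](=O)[O-])cc2/C1=C\c1cccc(OCc2cn(Cc3ccccc3)nn2)c1` — in a functional assay on PC-3 cells (Homo sapiens) for inhibition, read by MTT assay, with a stated time of 48 h (a higher number here means a weaker inhibitor, a lower number a stronger inhibitor), compound 1 gives only a limit, > 50000 nM.
Compound 2 `CC(=O)c1ccc2c(c1)/C(=C\c1cccc(OCc3cn(Cc4ccccc4)nn3)c1)C(=O)N2` — in this assay compound 2 gives only a limit, > 50000 nM.
Compound 3 `O=C1Nc2ccc(C(=O)c3ccccc3)cc2/C1=C\c1cccc(OCc2cn(Cc3ccccc3)nn2)c1` — in this assay compound 3 gives only a limit, > 50000 nM.

Compound 3 therefore stands at the same limit as the two other measured compounds, and none of the three has a number of its own. Compound 4 `COc1ccc(Cc2ccc3c(c2)/C(=C\c2cccc(OCc4cn(Cc5ccccc5)nn4)c2)C(=O)N3)cc1` is not yet measured; it differs from compound 3 in one place: 4-methoxybenzyl in place of benzoyl on an aromatic carbon.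

Within the data shown here, the measured steps that could bear on this change are the one from compound 1 to compound 2, a step that the two limits leave unreadable from compound 1 to compound 2, the one from compound 1 to compound 3, a step that the two limits leave unreadable from compound 1 to compound 3, and the one from compound 2 to compound 3, a step that the two limits leave unreadable from compound 2 to compound 3. None of them can be read, because of the limit of > 50000 nM in this assay, at which 3 of the 3 values shown sit. Among the measured compounds shown here, no measured step therefore tells how a 4-methoxybenzyl in place of benzoyl on that aromatic carbon should move the result, in either direction or at all.

With three compounds on the shared core all at the limit, compound 4 is expected to sit near that limit as well, and the step from compound 3 to compound 4 is estimated as a number no higher from compound 3 to compound 4 (the limit leaves the size open). For compound 4 the estimate in this assay is 50000 nM, with a range from 8000 nM to 300000 nM.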

Compound 4, half-maximal inhibitory concentration: 32200 nM
Compound 4: middle estimate off by 1.6-fold (0.19 log units), on the high side; the measured number falls inside the stated range.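

Among these compounds, compound 4 is the first compound on the shared core to give a number of its own in this assay, so a group on this aromatic carbon can bring a reading inside the measured range. Set against the earlier compounds, the change gives an at least 1.5-fold lower number from compound 3 to compound 4 (0.19 log units; that floor lies within the scatter), an at least 1.5-fold lower number from compound 2 to compound 4 (0.19 log units; that floor lies within the scatter) and an at least 1.5-fold lower number from compound 1 to compound 4 (0.19 log units; that floor lies within the scatter); each of these is only a floor, and the true gaps may be larger. The steps among compound 1, compound 2 and compound 3 still cannot be read: the limit of > 50000 nM in this assay, at which 3 of the 4 values shown sit.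

The compounds shown do not separate the methoxy group from the replacement of the carbonyl by a plain carbon link. Going by these compounds, how an unsubstituted benzyl, an amine or a carboxylic acid on this aromatic carbon would read also stays open.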